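The compounds below may be only part of what the source reports. "The series", "measured", "known", "first", "only" and "open" are said of these compounds alone.

compound 1 `CC(C)C[C@@H]1NC(=O)[C@H](CCCNC(N)=O)NC(=O)[C@H](CCCCN)NC(=O)[C@H](CC(=O)O)NC(=O)[C@H](CCCCN)NC(=O)CCNC1=O` gives 890 nM
compound 2 `CCC[C@@H]1NC(=O)[C@H](CCCNC(=N)N)NC(=O)[C@H](CCCCN)NC(=O)[C@H](CC(=O)O)NC(=O)[C@H](CCCCN)NC(=O)CCNC1=O` gives 452 nM
compound 3 `CC(C)C[C@@H]1NC(=O)[C@H](CCCNC(=N)N)NC(=O)[C@H](CN)NC(=O)[C@H](CC(=O)O)NC(=O)[C@H](CCCCN)NC(=O)CCNC1=O` gives > 5000 nM

All three values come from an assay on COS-7 cells for inhibition of disintegrin and metalloproteinase domain-containing protein 8 (Homo sapiens), read by ELISA, with a stated time of 6 h; a higher number here means a weaker inhibitor, a lower number a stronger inhibitor. For compound 3 the value is only a limit of the assay, and it sits at the limit of > 5000 nM in this assay, at which 1 of the 3 values shown sits. Compound 3 therefore stands apart from the other two, with no number of its own in this assay. Compound 4 `CC(C)C[C@@H]1NC(=O)[C@H](CCCNC(=N)N)NC(=O)[C@H](CCCN)NC(=O)[C@H](CC(=O)O)NC(=O)[C@H](CCCCN)NC(=O)CCNC1=O` differs from compound 3 in one place: 2-aminoethyl in place of amino on a saturated chain carbon bound to a saturated ring carbon. Among the measured compounds shown here, no measured step covers this change. For the measured compounds named here, a shift toward a stronger inhibitor in this assay is expected, beyond the usual scatter, as the change lengthens the side chain toward the one carried by compounds 1 and 2. The step from compound 3 to compound 4 is expected to be an at least 3.3-fold lower number from compound 3 to compound 4 (0.52 log units; beyond the scatter). Compound 4 is expected near 1500 nM, within 500 nM to 5000 nM.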

Compound 4, half-maximal inhibitory concentration: > 5000 nM
Compound 4 gave a limit, no number; the forecaster's own chance of this, stated with the estimate: 25%; middle value at least 3.3-fold (0.52 log units) from the limit.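

Compound 4 gives > 5000 nM, which is a limit and not a number. Among the compounds shown here, no step from compound 3 to compound 4 can be read, as both sit at the same limit: the limit of > 5000 nM in this assay, at which 2 of the 4 values shown sit. The compounds shown leave open whether 2-aminoethyl in place of amino shifts the value at all.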